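Adding a second fluoro to the benzyl group

The source may report more compounds than this note shows. Statements on the series, on what has been measured and on what is new or still open speak of the compounds shown alone.

Measured in a functional assay on SW 1116 cells (Homo sapiens) for antiproliferative activity, read by MTT assay, with a stated time of 24 h (on this read-out higher numbers stand for weaker inhibition and lower numbers for stronger inhibition), so far:
- Compound 1 `Clc1ccccc1CSc1nnc(-c2ccc3c(c2)OCCO3)n1-c1ccccc1` gives 9670 nM
- Compound 2 `Fc1ccccc1CSc1nnc(-c2ccc3c(c2)OCCO3)n1-c1ccccc1` gives 13600 nM

Compound 2 stands level with compound 1, with the two values inside the usual scatter. For the measured compounds named here, the only measured step is a 1.4-fold higher number from compound 1 to compound 2 (0.15 log units; within the scatter) and it swaps chloro for fluoro on an aromatic carbon. Compound 3 `Fc1cccc(F)c1CSc1nnc(-c2ccc3c(c2)OCCO3)n1-c1ccccc1` changes 2-fluorobenzyl to 2,6-difluorobenzyl, with fluoro in place of hydrogen on an aromatic carbon. Going by the values given here, that single small step is the only guide, so no shift beyond the scatter is expected in this assay here. The expected change is a 1.2-fold lower number from compound 2 to compound 3 (0.09 log units; within the scatter) and nothing larger is foreseen. The estimated value for compound 3 is 11000 nM (range 5500 nM to 22000 nM).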

Compound 3, half-maximal inhibitory concentration: 9010 nM
Beside the measured number, compound 3's estimate is 1.2-fold (0.09 log units) above it; low and high end bracket the measured number.
By their numbers in this assay, from the lowest: compounds 3, 1 and 2 (each within the scatter of the next).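

In this assay, a second fluoro that turns 2-fluorobenzyl into 2,6-difluorobenzyl gives a 1.5-fold lower number from compound 2 to compound 3 (0.18 log units; within the scatter), so this ring position accepts fluoro in place of hydrogen with no shift that can be told from scatter. The comparison with the chloro compound gives a 1.1-fold lower number from compound 1 to compound 3 (0.03 log units; within the scatter), so a single chloro and two fluoro groups also read alike here. No measurement shown offers an explanation for this. Still open, from the compounds shown here alone, is whether a methoxy group or an amine on this ring would move the number beyond the scatter.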